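The source may report more compounds than this note shows. Statements on the series, on what has been measured and on what is new or still open speak of the compounds shown alone.

Measured in a functional assay on HeLa cells (Homo sapiens) for antiproliferative activity, read by MTT assay, with a stated time of 48 h; a higher number here means a weaker inhibitor of growth, a lower number a stronger inhibitor of growth:
Compound 1 `CCOc1cc(NC(=O)CCCCC(=O)Nc2cc(-c3ccccc3)ccc2N)cc2c1OCC([N+](=O)[O-])=C2`: > 20000 nM (a limit of the assay, not a number)
Compound 2 `CCOc1cc(NC(=O)CCCCC(=O)Nc2cc(-c3ccc(C)s3)ccc2N)cc2c1OCC([N+](=O)[O-])=C2`: 18400 nM

For the measured compounds named here, compound 2 gives the only actual number so far. For compound 1 the reading is the limit of > 20000 nM in this assay, at which 1 of the 2 values shown sits. Compound 3 `CCOc1cc(NC(=O)CCCCC(=O)Nc2ccccc2N)cc2c1OCC([N+](=O)[O-])=C2` has hydrogen in place of 5-methylthiophen-2-yl on an aromatic carbon. Going by the values given here, the one measured step, an at least 1.0-fold lower number from compound 1 to compound 2 (0.03 log units; that floor lies within the scatter), exchanged one aromatic group for another and removed none, so it offers only indirect guidance. No change beyond the scatter is therefore expected in this assay, though the uncertainty is wide. The expected step is a 1.5-fold lower number from compound 2 to compound 3 (0.19 log units; within the scatter). The estimate for compound 3 is 12000 nM, with an expected range from 4000 nM to 25000 nM.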

Compound 3, concentration for 50% growth inhibition: 13100 nM
Compound 3: the middle estimate sits 1.1-fold (0.04 log units) below what was measured, within the range that was stated.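

In this assay, hydrogen in place of 5-methylthiophen-2-yl gives a 1.4-fold lower number from compound 2 to compound 3 (0.15 log units; within the scatter), so an aromatic group on this carbon shows no measurable gain over no group at all. Hydrogen in place of phenyl gives an at least 1.5-fold lower number from compound 1 to compound 3 (0.18 log units; that floor lies within the scatter), which also shows no change beyond the scatter. The reading for compound 1 is a limit, not a number: the limit of > 20000 nM in this assay, at which 1 of the 3 values shown sits.

Still open, going by these compounds, is whether a group of another kind on this aromatic carbon, such as an amine or a carboxylic acid, would move the number beyond the scatter.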